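A few compounds are considered here, and "the series" means these few. Any claim that something is new, unique, unknown or untested is made for them only; others in the source may bear on it.

Measured so far:
Compound 1, `CCCCOC(=O)NS(=O)(=O)c1ccc(CCC)cc1-c1ccc(Cn2c(C3CCCCC3)nc3ccccc32)cc1`, gives 130 nM in an assay on membranes from HEK293 cells for displacement of a labelled ligand from Type-2 angiotensin II receptor (Homo sapiens), read by radioligand binding; a higher number here means a weaker inhibitor, a lower number a stronger inhibitor.
Compound 2, `CCCCOC(=O)NS(=O)(=O)c1ccc(CCC)cc1-c1ccc(Cn2c(-c3nccs3)nc3ccccc32)cc1`, gives 5.1 nM in this assay.

Within the data shown here, compound 2 thus stands at the lower of the two numbers, and compound 1 is its only neighbour. Among the measured compounds shown here, the single measured step, a 25-fold lower number from compound 1 to compound 2 (1.41 log units; beyond the scatter), shows this position matters greatly. Compound 3, `CCCCOC(=O)NS(=O)(=O)c1ccc(CCC)cc1-c1ccc(Cn2c(CC(C)C)nc3ccccc32)cc1`, differs from compound 2 by isobutyl in place of 1,3-thiazol-2-yl on an aromatic carbon. Like cyclohexyl, isobutyl brings no hydrogen-bond acceptors and no aromatic ring, so much of that gain is expected to be lost again, as a 20-fold higher number from compound 2 to compound 3 (1.29 log units; beyond the scatter). Compound 3 is therefore estimated at 100 nM, with a range from 30 nM to 400 nM.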

Compound 3, inhibition constant: 19 nM
Compound 3: the middle estimate sits 5.3-fold (0.72 log units) above what was measured; the measured number lies below the stated range.
By their numbers in this assay, from the lowest: compound 2; then compound 3; then compound 1.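

On this aromatic carbon, a low number does not depend on an aromatic ring with hydrogen-bond acceptors: isobutyl has neither and gives only a 3.7-fold higher number from compound 2 to compound 3 (0.57 log units; beyond the scatter). The change from cyclohexyl to isobutyl, two groups without such a ring, also matters, with a 6.8-fold lower number from compound 1 to compound 3 (0.84 log units; beyond the scatter), so the weak result for compound 1 cannot be read as simply the lack of 1,3-thiazol-2-yl. No available evidence explains these differences. Still open, as far as these compounds go, is how a phenyl ring, a straight butyl chain or an amine at this carbon would compare with isobutyl and 1,3-thiazol-2-yl.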